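This account rests on a few compounds, and the source may have more. Where it says the series, first, only, none or still open, it means among the compounds named here.

Compounds measured in a functional assay on IGROV-1 cells (Homo sapiens) for inhibition, read by sulforhodamine B assay, with a stated time of 48 h; a higher number here means that more compound is tolerated, a lower number that less compound is tolerated:
compound 1 `COc1cc(-c2nn(-c3cccc(NC(=O)Nc4ccc(Cl)c(Cl)c4)c3)cc2-c2ccncc2)ccc1Cl`: > 50000 nM
compound 2 `O=C(Nc1cccc(-n2cc(-c3ccncc3)c(-c3ccc(Cl)c(O)c3)n2)c1)Nc1ccc(Cl)c(Cl)c1`: > 32500 nM

In this assay compound 1 gives > 50000 nM, which is a limit of the assay, not a number. Compound 2 likewise gives > 32500 nM, also a limit. Among the compounds with values here, the one measured step therefore reads a step that the two limits leave unreadable from compound 1 to compound 2, and the pair offers no readable size or direction. Compound 3 `COc1cc(-c2nn(-c3cccc(NC(=O)Nc4ccc(Cl)c(C(F)(F)F)c4)c3)cc2-c2ccncc2)ccc1Cl` differs from compound 1 in that (trifluoromethyl in place of chloro on an aromatic carbon). With compound 1 sitting at the limit of > 50000 nM in this assay, at which 1 of the 2 values shown sits, nothing points toward a change beyond the scatter. Compound 3 is expected to remain at a limit, estimated at 50000 nM within 15000 nM to 100000 nM, a step of a number no higher from compound 1 to compound 3 (the limit leaves the size open).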

Compound 3, concentration lethal to 50% of the cells: > 32500 nM
Compound 3: a limit, no number (the forecaster's own chance of this, stated with the estimate: 75%); the middle value does not contradict the limit.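

Compound 1 and compound 3 both sit at limits of this assay, not at numbers, so no step can be read between them. From the compounds shown here alone, the actual values of compound 1, compound 2 and compound 3 remain open.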